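From propoxy to amino on compound 3

The compounds below may be only part of what the source reports. "The series", "measured", "known", "first", "only" and "open" are said of these compounds alone.

Measured so far in an ADME assay on MDCK cells (Canis lupus familiaris) for cytotoxicity, read by MTT assay, with a stated time of 48 h; a lower number here means that less compound is tolerated, a higher number that more compound is tolerated:
- compound 1 `NC(=O)c1c(NC(=O)c2nc3nccc(-c4ccccc4)n3n2)sc2c1CCCCC2`: > 200000 nM
- compound 2 `NC(=O)c1c(NC(=O)c2nc3ncc(-c4ccccc4)cn3n2)sc2c1CCCCC2`: 100000 nM
- compound 3 `CCCOc1ccc(C(=O)Nc2nc3nc(-c4ccccc4)cc(C)n3n2)cc1`: 247000 nM

The entry for compound 1, > 200000 nM, is a limit of the assay and not a number. Among the two true numbers, compound 3 stands highest at 247000 nM, and the gap down to compound 2 at 100000 nM lies beyond the scatter.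

Compound 4 `Cc1cc(-c2ccccc2)nc2nc(NC(=O)c3ccc(N)cc3)nn12` has amino in place of propoxy on an aromatic carbon, para to a large group: amino in place of propoxy on an aromatic carbon. Within the data shown here, no two measured compounds differ in one place only, so no measured step shows what this change does. The expectation therefore rests on the high number of compound 3, 247000 nM, and on the absence of any low reading so far. No step beyond the scatter is expected in this assay, in either direction. The expected change is a 1.1-fold lower number from compound 3 to compound 4 (0.05 log units; within the scatter). The estimate for compound 4 is 220000 nM, with an expected range from 100000 nM to 400000 nM.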

Compound 4, half-maximal cytotoxic concentration: > 250000 nM
Compound 4: only a limit was reported; the forecaster's own chance of this, stated with the estimate: 50%; at least 1.1-fold (0.05 log units) between middle value and limit.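

In this assay, compound 4 gives > 250000 nM, which is a limit of the assay and not a number. Among these compounds, the computed change is an at least 1.0-fold higher number from compound 3 to compound 4 (0.00 log units; that floor lies within the scatter), the first step that isolates a single change, here at an aromatic carbon para to a large group: replacing propoxy with amino gives no sign that less compound is tolerated. How large the rise may be stays unread: the limit of > 250000 nM in this assay, at which 1 of the 4 values shown sits.

The compounds shown leave open whether another group at this place, such as a carboxylic acid or a methoxy group, would lower the number in a reading below the limit. They also leave open whether amino in place of propoxy would give the same outcome on a different core, such as the core of compound 1.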